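A few compounds are considered here, and "the series" means these few. Any claim that something is new, unique, unknown or untested is made for them only; others in the source may bear on it.

Compound 3 `C[C@@H](c1ccc(NC(=O)N2CC(c3cccnc3)C2)cc1)N1Cc2ccccc2C1=O` gives 1.5 nM in a functional assay on A2780 cells (Homo sapiens) for antiproliferative activity, read by CellTiter-Glo, with a stated time of 72 h; on this read-out lower numbers stand for stronger inhibition and higher numbers for weaker inhibition. Compound 1 `O=C(Nc1ccc(CN2Cc3ccccc3C2=O)cc1)N1CC(c2cccnc2)C1` gives 0.6 nM, which leaves compound 3 with the higher of the two single numbers in the series. Compound 2 `O=C(Nc1ccc(CN2Cc3ccccc3C2=O)cc1)N1CCC(c2cccnc2)C1` gives > 2500 nM; 1030 nM (2 entries). Compound 2 carries the same group as compound 1, so it offers no test of the exchange considered here.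

Compound 4 `C[C@H](NC(=O)c1cccc(F)c1)c1ccc(NC(=O)N2CC(c3cccnc3)C2)cc1` differs from compound 3 by one exchange: a group of 10 heavy atoms (7 carbon, 1 nitrogen, 1 oxygen, 1 fluorine; one six-membered aromatic ring of carbon only) in place of a group of 10 heavy atoms (8 carbon, 1 nitrogen, 1 oxygen; one five-membered non-aromatic ring with 1 hetero atom, one six-membered aromatic ring of carbon only), on a saturated chain carbon bound to an aromatic carbon and a saturated chain carbon. Among the compounds with values here, the only measured step at this carbon is a 2.5-fold higher number from compound 1 to compound 3 (0.40 log units; beyond the scatter), which is modest and beyond the scatter, but it adds a methyl and does not replace the group. Within the data shown here, no measured step covers the exchange itself, so the expectation is loose: a modest move toward a higher number in this assay, somewhat larger than the methyl step. The expected change is a 2.7-fold higher number from compound 3 to compound 4 (0.43 log units; beyond the scatter). For compound 4 the estimated value is 4 nM, with an expected range of 0.8 nM to 25 nM.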

Compound 4, half-maximal inhibitory concentration: 2.3 nM
Estimate against measurement, compound 4: 1.7-fold (0.24 log units) above; the range from low to high includes it.
By their numbers in this assay, from the lowest: compound 1; then compounds 3 and 4 (each within the scatter of the next).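

In this assay, the exchange on the saturated chain carbon gives a 1.5-fold higher number from compound 3 to compound 4 (0.19 log units; within the scatter), whereas the earlier step at this carbon covered only an added methyl. In this pair, the five-membered non-aromatic ring of the leaving group can give way to ((3-fluorophenyl)carbonyl)amino, which has only a six-membered aromatic ring and brings 1 hydrogen-bond donor, with no change beyond the scatter. The available evidence does not bear on this exchange, so no property of either group can be tied to the result.

The compounds shown leave open what the fluorine contributes to the entering group, and whether an amine or a carboxylic acid would fit on the same carbon. They also leave open whether the exchange would read the same on the unmethylated chain carbon of compound 1.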